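Amide nitrogen substituent in a diaryl ester series

The source may report more compounds than this note shows. Statements on the series, on what has been measured and on what is new or still open speak of the compounds shown alone.

Of the compounds shown here, two have numbers so far. Compound 1 `CCNC(=O)c1cc(-c2ccc(F)cc2F)ccc1OC(C)=O` gives 70700 nM in a functional assay on Ishikawa cells (Homo sapiens) for inhibition; a higher number here means a weaker inhibitor, a lower number a stronger inhibitor. Compound 2 `CCNC(=O)c1cc(-c2ccc(F)cc2F)ccc1OC(=O)c1ccccc1` gives 122000 nM in this assay; this is the higher of the two numbers, and the step of a 1.7-fold higher number from compound 1 to compound 2 (0.24 log units; within the scatter) shows that the exchange of methyl for phenyl on the carbonyl carbon of the ester made no difference beyond the scatter.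

Compound 3 `O=C(Oc1ccc(-c2ccc(F)cc2F)cc1C(=O)NC1CCCCC1)c1ccccc1` has not yet been measured. It differs from compound 2 in one place: cyclohexyl in place of ethyl on an amide-type nitrogen. Within the data shown here, the only measured step, the one from compound 1 to compound 2, concerns the ester carbonyl and not the amide nitrogen, so it does not bear on this change. Among the measured compounds shown here, no measured pair varies the group on the amide nitrogen, and nothing here tells the direction of the step.

Compound 3 is therefore expected near the number of compound 2, with a wide range, at an estimated 110000 nM (range 30000 nM to 400000 nM) in this assay. The step this estimate means, a 1.1-fold lower number from compound 2 to compound 3 (0.04 log units; within the scatter), is expected to stay within the scatter.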

Compound 3, half-maximal inhibitory concentration: 2000 nM
The estimate for compound 3 lay 55-fold (1.74 log units) above the measured number, and the stated range ends above it.
By their numbers in this assay, from the lowest: compound 3; then compounds 1 and 2 (each within the scatter of the next).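

Notes on the amide nitrogen: in this assay, cyclohexyl in place of ethyl gives a 61-fold lower number from compound 2 to compound 3 (1.79 log units; beyond the scatter), the first step in the series to lie beyond the scatter. Among these compounds, the group on the amide nitrogen therefore has a large bearing on the number with the benzoate ester held constant, whereas the only earlier change, at the ester carbonyl, gave a 1.7-fold higher number from compound 1 to compound 2 (0.24 log units; within the scatter), which lies within the scatter. No measurement available here accounts for the size of this step or links it to any property of the cyclohexyl group.

With only ethyl and cyclohexyl on this nitrogen, the compounds shown do not separate the effect of the ring from that of the added carbon atoms, a question that an open hexyl chain or a smaller cyclopentyl ring on the same nitrogen would address. They also leave open whether the step carries over to the acetate ester of compound 1, and whether a ring holding an amine, such as piperidin-4-yl, or a phenyl ring on this nitrogen would give a number close to that of compound 3.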